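Working notes: from compound 3 to compound 4

A few compounds are considered here, and "the series" means these few. Any claim that something is new, unique, unknown or untested is made for them only; others in the source may bear on it.

In a functional assay on MCF7 cells (Homo sapiens) for cytotoxicity, read by MTT assay, with a stated time of 72 h (a higher number here means a weaker inhibitor, a lower number a stronger inhibitor), compound 1 (`CCCC[S+]([O-])CCCCN=C=S`) gives 5840 nM and compound 2 (`[O-][S+](CCCCN=C=S)C1CCCC1`) gives 4450 nM while compound 3 (`[O-][S+](CCCCN=C=S)Cc1ccccc1`) gives 3300 nM as its reading. Compound 3 stands within the scatter of both other compounds, so the three cannot be ranked. The change nitro in place of hydrogen on an aromatic carbon puts nitro in place of hydrogen on an aromatic carbon, para to a large group, and leads to compound 4 (`O=[N+]([O-])c1ccc(C[S+]([O-])CCCCN=C=S)cc1`). For the measured compounds named here, no measured pair differs in one place, so the data do not size this change. In this assay the expected step is a 1.2-fold lower number from compound 3 to compound 4 (0.07 log units; within the scatter) and no shift beyond the scatter is expected. Compound 4 is estimated at 2800 nM (expected range 1100 nM to 6500 nM).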

Compound 4, half-maximal inhibitory concentration: 7770 nM
Beside the measured number, compound 4's estimate is 2.8-fold (0.44 log units) below it; the measured number lies above the stated range.
By their numbers in this assay, from the lowest: compounds 3, 2, 1 and 4 (each within the scatter of the next, the first and the last beyond it).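

In this assay, for the compounds shown here, nitro in place of hydrogen on an aromatic carbon, para to a large group, gives a 2.4-fold higher number from compound 3 to compound 4 (0.37 log units; beyond the scatter) and is the first step between compounds that differ in one place. This position therefore does not tolerate every substituent without a change in the number, and nitro moves it towards weaker inhibition. Nothing available bears on the reason for this step. From the compounds shown here alone, with only nitro at this position, it remains open whether the step belongs to nitro alone. An amine or a carboxylic acid at the same place could separate the two readings.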